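Hydroxyphenyl for methoxyphenyl on a tetradecyl serine imine

The source may report more compounds than this note shows. Statements on the series, on what has been measured and on what is new or still open speak of the compounds shown alone.

Measured compounds:
compound 1 `CCCCCCCCCCCCCCNC(=O)[C@H](CO)/N=C/c1cccc(OC)c1` gives 31300 nM
compound 2 `CCCCCCCCCCCCCCNC(=O)[C@H](CO)/N=C/c1ccccc1O` gives 19000 nM
compound 3 `CCCCCCCCCCCCCCNC(=O)[C@H](CO)/N=C/c1cccc([N+](=O)[O-])c1` gives 104000 nM

The three compounds were tested in a functional assay on cells (Homo sapiens) for cytotoxicity, read by MTT assay, with a stated time of 24 h; a higher number here means a weaker inhibitor, a lower number a stronger inhibitor. Compound 1 stands second highest of the three numbers. Its nearest neighbour is compound 2, with a 1.6-fold lower number from compound 1 to compound 2 (0.22 log units; within the scatter), and its furthest is compound 3, with a 3.3-fold higher number from compound 1 to compound 3 (0.52 log units; beyond the scatter). Between the other two, a 5.5-fold higher number from compound 2 to compound 3 (0.74 log units; beyond the scatter).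

The unmeasured compound 4 `CCCCCCCCCCCCCCNC(=O)[C@H](CO)/N=C/c1ccc(O)cc1` differs from compound 1 in one place: 4-hydroxyphenyl in place of 3-methoxyphenyl on a carbon with a double bond to nitrogen.

Among the compounds with values here, the step that bears most directly on this change is the one from compound 1 to compound 2, where a hydroxyphenyl also replaced the methoxyphenyl, and the number moved only within the scatter. The step to compound 3 concerns a nitro group and is less relevant. Compound 4 is therefore expected to show no step beyond the scatter, with a 1.2-fold lower number from compound 1 to compound 4 (0.08 log units; within the scatter). The estimate for compound 4 is 26000 nM, with a range from 9000 nM to 75000 nM.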

Compound 4, half-maximal inhibitory concentration: 19300 nM
Compound 4: middle estimate off by 1.3-fold (0.13 log units), on the high side; the range from low to high includes it.
By their numbers in this assay, from the lowest: compounds 2, 4 and 1 (each within the scatter of the next); then compound 3.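

In this assay, the step to 4-hydroxyphenyl, a 1.6-fold lower number from compound 1 to compound 4 (0.21 log units; within the scatter), stays within the scatter, just as the earlier step to 2-hydroxyphenyl did. The new information is the direct comparison of the two hydroxyphenyl compounds: a 1.0-fold higher number from compound 2 to compound 4 (0.01 log units; within the scatter) shows that these two groups cannot be told apart at this place in this assay. Within the data shown here, the step of a 5.4-fold lower number from compound 3 to compound 4 (0.73 log units; beyond the scatter) lies beyond the scatter, so compound 3, with its 3-nitrophenyl group, remains the one compound of the four set apart from the others.

Nothing available here accounts for these numbers. From the compounds shown here alone, it remains open whether an amine or a carboxylic acid on the phenyl ring, or a longer chain in place of the tetradecyl chain, would move the number as far as the nitro group did.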